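Chloro placement on the pyridyl alkyne tail

The source may report more compounds than this note shows. Statements on the series, on what has been measured and on what is new or still open speak of the compounds shown alone.

Measured so far:
compound 1 `O=C(O)CCc1ccc(C#Cc2ccc(Cl)nc2)cc1`, 708 nM in an in vitro functional assay on 1321-N1 cells for agonist activity at Free fatty acid receptor 1 (Homo sapiens), read by fluorescence, spectrophotometry and calcium flux; a lower number here means that less compound is needed, a higher number that more compound is needed for the effect
compound 2 `O=C(O)CCc1ccc(C#Cc2cccnc2)cc1`, 6030 nM in this assay

Compound 2 gives the highest of the two numbers in this assay; the nearest is compound 1, separated by an 8.5-fold higher number from compound 1 to compound 2 (0.93 log units; beyond the scatter). Compound 3 `O=C(O)CCc1ccc(C#Cc2cccnc2Cl)cc1` differs from compound 2 by chloro in place of hydrogen on an aromatic carbon. Among the compounds with values here, only one measured step bears on it, an 8.5-fold higher number from compound 1 to compound 2 (0.93 log units; beyond the scatter), and that step concerns chloro at a different place on the same ring; its size is modest but beyond the scatter. Returning chloro, now at the new place, is therefore expected to lower the number, though less surely. The estimate for compound 3 in this assay is 2000 nM (range 500 nM to 8000 nM), meaning an expected 3.0-fold lower number from compound 2 to compound 3 (0.48 log units; beyond the scatter).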

Compound 3, half-maximal effective concentration: 603 nM
Compound 3: middle estimate off by 3.3-fold (0.52 log units), on the high side; the measured number falls inside the stated range.
By their numbers in this assay, from the lowest: compounds 3 and 1 (each within the scatter of the next); then compound 2.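

In this assay, chloro on the aromatic carbon next to the ring nitrogen and ortho to a large group gives a 10-fold lower number from compound 2 to compound 3 (1.00 log units; beyond the scatter), so a second chloro placement on this ring also goes with a lower number. Compound 3 at 603 nM and compound 1 at 708 nM lie within the scatter of each other, so these two placements cannot be separated here. No measurement shown accounts for this step.

On these data alone, whether this place depends on chloro specifically remains open, since fluoro, methyl, methoxy or an amine could be compared there. As far as these compounds go, how two chloro groups on the same ring would behave also remains open.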